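Removing the methyl of compound 2: no direct precedent

A few compounds are considered here, and "the series" means these few. Any claim that something is new, unique, unknown or untested is made for them only; others in the source may bear on it.

Three compounds share one core and differ only in the aryl group on the carbonyl carbon. Compound 1 `COc1ccc(C(=O)NCc2ccc(CNS(=O)(=O)c3ccc(C)cc3)cc2)cc1` gives 100 nM in an assay on MDA-MB-231 cells for binding affinity to C-X-C chemokine receptor type 4 (Homo sapiens), read by immunofluorescence and microscopy, with stated times of 10 min and 30 min; a lower number here means that less compound is needed, a higher number that more compound is needed for the effect. Compound 2 `Cc1ccc(S(=O)(=O)NCc2ccc(CNC(=O)c3ccc(Cl)cc3)cc2)cc1` gives 10 nM, and compound 3 `Cc1ccc(S(=O)(=O)NCc2ccc(CNC(=O)c3cccc(Cl)c3)cc2)cc1` gives 100 nM. The steps read a 10-fold lower number from compound 1 to compound 2 (1.00 log units; beyond the scatter), a 10-fold higher number from compound 2 to compound 3 (1.00 log units; beyond the scatter) and no change at the digits printed from compound 1 to compound 3 (within the scatter). Compound 2 therefore holds the lowest number of the three, beyond the scatter against both compound 1 and compound 3.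

Compound 4 `O=C(NCc1ccc(CNS(=O)(=O)c2ccccc2)cc1)c1ccc(Cl)cc1` is the next member. Relative to compound 2 the change is hydrogen in place of methyl on an aromatic carbon. Among the measured compounds shown here, none of the measured steps bears on this end of the molecule: all three exchange the group on the carbonyl carbon and leave the 4-methylphenyl untouched. The series gives no guide to how the number moves when that methyl is removed, so the starting point is compound 2 itself, with a wide band around it. No step beyond the scatter is expected in either direction, but a drift toward a higher number cannot be excluded.

Compound 4 is estimated at 20 nM in this assay, within 7 nM to 60 nM, which is expected to mean a 2.0-fold higher number from compound 2 to compound 4 (0.30 log units; within the scatter).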

Compound 4, effective concentration (reported as EC, without a stated level of effect): 100 nM
The estimate for compound 4 lay 5.0-fold (0.70 log units) below the measured number, outside the stated range (above it).
By their numbers in this assay, from the lowest: compound 2; then compounds 1, 3 and 4 (each within the scatter of the next).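

Among the compounds shown here, the 4-methylphenyl end is not a silent part of the molecule: in this assay, the first step at this position, a 10-fold higher number from compound 2 to compound 4 (1.00 log units; beyond the scatter), is beyond the scatter, so the loss of a single methyl from the aromatic carbon para to a large group counts here. That step is printed at the same size as a 10-fold higher number from compound 2 to compound 3 (1.00 log units; beyond the scatter), so the low number of compound 2 is lost with one change at either end of the molecule, and the methyl matters as much in this pair as the place of the chloro on the other aryl group does in its own. Nothing available here accounts for the size of the step.

On these data alone, whether the methyl itself is required or other groups on that aromatic carbon would serve equally remains open, for instance an ethyl, a methoxy or a trifluoromethyl group, any of which could keep, lose or improve on the number of compound 2. Also open, as far as these compounds go, is whether removing the methyl has the same effect with 4-methoxyphenyl or 3-chlorophenyl on the carbonyl carbon, since this step is read only with 4-chlorophenyl there.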